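Swapping the Cyclohexyl Ring on an Amide

The source may report more compounds than this note shows. Statements on the series, on what has been measured and on what is new or still open speak of the compounds shown alone.

Measured in a functional assay on PC-3 cells (Homo sapiens) for antiproliferative activity, read by sulforhodamine B assay, with a stated time of 72 h; on this read-out lower numbers stand for stronger inhibition and higher numbers for weaker inhibition:
Compound 1 (`COc1ncc(-c2ccc3ncc(NC(=O)C4CCCCC4)c(OC)c3c2)cc1NS(=O)(=O)c1ccc(F)cc1F`) gives 6630 nM
Compound 2 (`COc1ncc(-c2ccc3ncc(NCC4CCCCC4)c(OC)c3c2)cc1NS(=O)(=O)c1ccc(F)cc1F`) gives 9000 nM
Compound 3 (`COc1ncc(-c2ccc3ncc(NCC4CCN(S(C)(=O)=O)CC4)c(OC)c3c2)cc1NS(=O)(=O)c1ccc(F)cc1F`) gives 2850 nM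

Compound 1 sits within the scatter of compound 2 (a 1.4-fold higher number from compound 1 to compound 2 (0.13 log units; within the scatter)), while compound 3 stands lower (a 2.3-fold lower number from compound 1 to compound 3 (0.37 log units; beyond the scatter)). Compound 4 (`COc1ncc(-c2ccc3ncc(NC(=O)CN4CCCC(O)C4)c(OC)c3c2)cc1NS(=O)(=O)c1ccc(F)cc1F`) keeps the amide of compound 1 but changes the group on its carbonyl carbon ((3-hydroxypiperidin-1-yl)methyl in place of cyclohexyl on a carbonyl carbon). Within the data shown here, no measured step makes this exact swap. The closest guide also replaces cyclohexyl with a ring holding a hetero atom (a 3.2-fold lower number from compound 2 to compound 3 (0.50 log units; beyond the scatter)), although compound 3 has no carbonyl and carries a different ring. The change from carbonyl to a saturated link, seen in the first step above, stayed within the scatter. One modest step is thin evidence, so the direction is only tentative. In this assay a modest move toward a lower number is therefore expected, and a 1.9-fold lower number from compound 1 to compound 4 (0.28 log units; within the scatter) is the estimated step. Compound 4 is expected at 3500 nM with an estimated range from 1000 nM to 10000 nM when tested.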

Compound 4, half-maximal inhibitory concentration: 1340 nM
Compound 4: middle estimate off by 2.6-fold (0.42 log units), on the high side, within the range that was stated.
By their numbers in this assay, from the lowest: compound 4; then compound 3; then compounds 1 and 2 (each within the scatter of the next).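

In this assay this is the first step shown with the amide kept and only the group on its carbonyl carbon changed: (3-hydroxypiperidin-1-yl)methyl in place of cyclohexyl gives a 4.9-fold lower number from compound 1 to compound 4 (0.69 log units; beyond the scatter). The same group also beats the two saturated links on that nitrogen, with a 2.1-fold lower number from compound 3 to compound 4 (0.33 log units; beyond the scatter) and a 6.7-fold lower number from compound 2 to compound 4 (0.83 log units; beyond the scatter), so compound 4 is the most potent of the four in this test. No supporting measurement bears on why this change lowers the number.

The ring nitrogen, the hydroxyl and the methyl link all enter together, so the compounds shown leave open which of them matters. A piperidin-1-ylmethyl group without the hydroxyl, or a morpholin-4-ylmethyl group, on the same carbonyl carbon would help separate these parts.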